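A few compounds are considered here, and "the series" means these few. Any claim that something is new, unique, unknown or untested is made for them only; others in the source may bear on it.

Three compounds share one core and differ only in the aryl group carried on one urea nitrogen. Compound 1 `Cc1ccc(NC(=O)Nc2cccc(-c3nc(-c4ccc(NC(=O)c5cccnc5)cc4Cl)no3)c2)cc1` carries a 4-methylphenyl there, and in a functional assay on MDA-MB-231 cells (Homo sapiens) for antiproliferative activity, read by MTT assay, with a stated time of 72 h (a higher number here means a weaker inhibitor, a lower number a stronger inhibitor), compound 1 gives 3500 nM. Compound 2 `COc1cccc(NC(=O)Nc2cccc(-c3nc(-c4ccc(NC(=O)c5cccnc5)cc4Cl)no3)c2)c1` carries a 3-methoxyphenyl instead, and in this assay compound 2 gives 6700 nM, a change of a 1.9-fold higher number from compound 1 to compound 2 (0.28 log units; within the scatter). Compound 3 `CS(=O)(=O)Nc1cccc(NC(=O)Nc2cccc(-c3nc(-c4ccc(NC(=O)c5cccnc5)cc4Cl)no3)c2)c1` carries a 3-(methanesulfonamido)phenyl. In this assay compound 3 reaches only a limit, > 10000 nM. That limit still sets it an at least 2.8-fold higher number from compound 1 to compound 3 (0.45 log units; beyond the scatter), while against compound 2 the step is an at least 1.4-fold higher number from compound 2 to compound 3 (0.17 log units; that floor lies within the scatter); compound 3 thus sits at the limit of > 10000 nM in this assay, at which 1 of the 3 values shown sits, and nothing more exact is known of it.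

Compound 4 `CC(=O)Nc1ccc(NC(=O)Nc2cccc(-c3nc(-c4ccc(NC(=O)c5cccnc5)cc4Cl)no3)c2)cc1Br` is the next step: 4-acetamido-3-bromophenyl in place of 3-(methanesulfonamido)phenyl on an amide-type nitrogen. Going by the values given here, no measured pair swaps one whole aryl group for another of this kind, but every measured step did change this same group, and each moved the number only modestly, from the value of compound 1 to the limit of compound 3. The expected step of an at least 1.2-fold lower number from compound 3 to compound 4 (0.09 log units; that floor lies within the scatter) is therefore small, with no direction clearly beyond the scatter. Compound 4 is expected to give about 8000 nM, within a range from 2500 nM to 25000 nM.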

Compound 4, half-maximal inhibitory concentration: 1000 nM
Compound 4: the middle estimate sits 8.0-fold (0.90 log units) above what was measured, and the stated range ends above it.
By their numbers in this assay, from the lowest: compound 4; then compounds 1 and 2 (each within the scatter of the next). At a limit, above all of these: compound 3.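

Until now, no aryl group on this amide-type nitrogen had brought the number in this assay below that of compound 1, and 4-acetamido-3-bromophenyl does so, with a 3.5-fold lower number from compound 1 to compound 4 (0.54 log units; beyond the scatter). Going by these compounds alone, the same group also stands clear of the two other aryl groups, with a 6.7-fold lower number from compound 2 to compound 4 (0.83 log units; beyond the scatter) and an at least 10-fold lower number from compound 3 to compound 4 (1.00 log units; beyond the scatter), so this position can move the number in the favourable direction as well as the unfavourable one, and by more than the earlier steps showed. The last of these steps is only a floor, since compound 3 is known only by a limit: the limit of > 10000 nM in this assay, at which 1 of the 4 values shown sits.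

The entering group brings an acetamido and a bromine together, so the compounds shown leave open which of the two accounts for the lower number, or whether it takes both; a 4-acetamidophenyl and a 3-bromophenyl would separate them. Also open, on these data alone, is whether other groups on this phenyl ring, such as an amine or a carboxylic acid, would take the number lower still or back up.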